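This account rests on a few compounds, and the source may have more. Where it says the series, first, only, none or still open, it means among the compounds named here.

Going by the values given here, in a functional assay on HCT-116 cells (Homo sapiens) for inhibition, read by CCK-8 assay, with a stated time of 48 h (a higher number here means a weaker inhibitor, a lower number a stronger inhibitor), compound 2 (`COc1cc(-c2ccnc3cc(-c4ccc5ccn(C)c5c4)nn23)cc(OC)c1OC`) gives 1040 nM, the higher of the two numbers so far, and compound 1 (`COc1cc(-c2ccnc3cc(-c4ccc5c(ccn5C)c4)nn23)cc(OC)c1OC`) gives 39 nM. Compound 3 (`COc1ccc(-c2cc3nccc(-c4cc(OC)c(OC)c(OC)c4)n3n2)cc1N`) has 3-amino-4-methoxyphenyl in place of 1-methyl-1H-indol-6-yl on an aromatic carbon. Among the compounds with values here, the only measured step at this place, a 27-fold higher number from compound 1 to compound 2 (1.43 log units; beyond the scatter), is large, so a change here can move the number far. Within the data shown here, no measured compound carries the entering group, which keeps the expectation loose. A large drop is expected in this assay, an estimated 15-fold lower number from compound 2 to compound 3 (1.17 log units; beyond the scatter). For compound 3 the expected value is 70 nM, with an estimated range of 10 nM to 500 nM.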

Compound 3, half-maximal inhibitory concentration: 251 nM
Compound 3: the middle estimate sits 3.6-fold (0.55 log units) below what was measured; low and high end bracket the measured number.
By their numbers in this assay, from the lowest: compound 1; then compound 3; then compound 2.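

In this assay the exchange of 1-methyl-1H-indol-6-yl for the single-ring 3-amino-4-methoxyphenyl gives a 4.1-fold lower number from compound 2 to compound 3 (0.62 log units; beyond the scatter), so the fused indole is not required at this place. Against 1-methyl-1H-indol-5-yl the same group gives a 6.4-fold higher number from compound 1 to compound 3 (0.81 log units; beyond the scatter), which leaves compound 1 lowest of the three. Nothing measured accounts for this order. As far as these compounds go, it remains open whether the amino or the methoxy group of 3-amino-4-methoxyphenyl carries the gain over compound 2: a hydroxyl in place of the amino group, or a plain phenyl, would separate the two.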